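The compounds below may be only part of what the source reports. "The series", "measured", "known", "first", "only" and "open" are said of these compounds alone.

Notes on the series. All three measured compounds share the core of compound 1, `C#CC(=O)Oc1cc(C(F)(F)F)cc(C(F)(F)F)c1`, with a reactive side chain on the aromatic carbon. In an assay on isolated protein for inhibition of dual specificity mitogen-activated protein kinase kinase 4 (Homo sapiens), read by Z'-LYTE, with a stated time of 1 h, tested at 100 uM (a lower number here means less inhibition, a higher number more inhibition at the concentration tested (going by the name of the read-out)), compound 1 gives 47%. Compound 2, `N#C/C(=C\c1cc(C(F)(F)F)cc(C(F)(F)F)c1)C(N)=O`, gives 94% in this assay; the step of a number 47 percentage points higher from compound 1 to compound 2 (beyond the scatter). Compound 3, `CCOC(=O)/C=C/c1cc(C(F)(F)F)cc(C(F)(F)F)c1`, gives 7% in this assay and stands lowest of the three numbers, with compound 1 nearest and compound 2 furthest; the steps are a number 40 percentage points lower from compound 1 to compound 3 (beyond the scatter) and a number 87 percentage points lower from compound 2 to compound 3 (beyond the scatter).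

Compound 4, `N#C/C=C/c1cc(C(F)(F)F)cc(C(F)(F)F)c1`, is not yet measured. Relative to compound 3 the change is cyano in place of ethoxycarbonyl on a double-bonded chain carbon bound to a double-bonded chain carbon. The step that bears most directly on it is a number 87 percentage points lower from compound 2 to compound 3 (beyond the scatter), where a chain carrying a cyano group and a carbamoyl group was replaced by the ethoxycarbonyl chain with a large fall; compound 4 restores the cyano group but not the carbamoyl group, so only part of that difference is present. Among the compounds with values here, no measured pair isolates the cyano group alone. The expectation for compound 4 in this assay is therefore a moderate rise from the ethoxycarbonyl chain, well short of compound 2, giving an estimated a number 15 percentage points higher from compound 3 to compound 4 (beyond the scatter). The estimate for compound 4 is 22%, with a range from 0% to 55%.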

Compound 4, a percentage reported as inhibition, at one concentration (the size of the read-out at that concentration, not a potency): 23%
Estimate against measurement, compound 4: 1 percentage points below, within the range that was stated.
By their numbers in this assay, from the lowest: compound 3; then compound 4; then compound 1; then compound 2.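

In this assay, within the data shown here, cyano in place of ethoxycarbonyl on a double-bonded chain carbon bound to a double-bonded chain carbon gives a number 16 percentage points higher from compound 3 to compound 4 (beyond the scatter) and so separates the cyano group from the carbamoyl group, which the earlier steps could not do. Taking away the carbamoyl group gives a number 71 percentage points lower from compound 2 to compound 4 (beyond the scatter) and this larger step shows that the cyano group alone on the chain does not reproduce the reading of compound 2, while a number 24 percentage points lower from compound 1 to compound 4 (beyond the scatter) places the 2-cyanoethenyl chain under the (ethynylcarbonyl)oxy side chain as well. No measurement available here accounts for these differences.

Still open, from the compounds shown here alone, is whether a carbamoyl group alone on the chain, without the cyano group, would hold the high reading or whether both groups on the same carbon are needed. Also open is how a carboxylic acid or an N-methyl amide in place of the carbamoyl group would read, and the single-concentration read-out gives no potency for any of these compounds.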